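Moving the pyrazole attachment point on a benzamide series

The source may report more compounds than this note shows. Statements on the series, on what has been measured and on what is new or still open speak of the compounds shown alone.

In a functional assay on MV4-11 cells (Homo sapiens) for antiproliferative activity, with a stated time of 6 days, tested at 1.56 uM (on this read-out higher numbers stand for a stronger effect at the one concentration tested and lower numbers for a weaker effect), the three measured compounds give:

Compound 1, `CNC(=O)N1CCCc2ccc(NC(=O)c3ccc(-c4ccncc4)cc3)cc21`, gives 37.6%.
Compound 2, `CNC(=O)N1CCCc2ccc(NC(=O)c3cccc(-c4cc[nH]n4)c3)cc21`, gives 27.3%.
Compound 3, `CNC(=O)N1CCCc2ccc(NC(=O)c3ccccc3-c3ccccc3)cc21`, gives 10.7%.

Compound 2 stands second of the three numbers. Compound 1 lies higher, by a gap beyond the usual scatter, and compound 3 lies lower, by a gap also beyond the scatter. All three share the same core; they differ only in the ring that hangs from the benzamide.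

Compound 4, `CNC(=O)N1CCCc2ccc(NC(=O)c3cccc(-c4cn[nH]c4)c3)cc21`, is built from the same atoms as compound 2, joined differently: 1H-pyrazol-4-yl in place of 1H-pyrazol-3-yl on an aromatic carbon. The ring keeps its donor and acceptor; only the carbon through which it is attached to the six-membered ring changes.

Within the data shown here, no pair of measured compounds shows this kind of change, so there is no step to lean on. The expected step from compound 2 to compound 4 in this assay is a number 1.3 percentage points lower from compound 2 to compound 4 (within the scatter), which is judged to stay within the scatter and carries no firm direction. Compound 4 is therefore estimated at 26%, with a range from 10% to 45%.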

Compound 4, a percentage reported as inhibition, at one concentration (the size of the read-out at that concentration, not a potency): 27.9%
For compound 4 the middle estimate is 1.9 percentage points below the measured one; low and high end bracket the measured number.
By their numbers in this assay, from the lowest: compound 3; then compounds 2, 4 and 1 (each within the scatter of the next, the first and the last beyond it).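

Replacing 1H-pyrazol-3-yl with 1H-pyrazol-4-yl gives a number 0.6 percentage points higher from compound 2 to compound 4 (within the scatter) in this assay. Among these compounds, this is the first comparison here in which only one place changes, and on this aromatic carbon, meta to a large group, the read-out does not separate the two attachment points of the pyrazole. No measurement at hand bears on why the two compounds read alike.

As far as these compounds go, compound 1 and compound 3 differ from compound 4 in more than one place, so whether the attachment point matters equally elsewhere on the ring remains open. Also open, from the compounds shown here alone, is what an amine, a carboxylic acid or a longer alkyl chain would do on this same carbon, and whether full dose-response curves would separate compound 2 and compound 4.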